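Lengthening the Acid Chain on a Shared Core

The source may hold more compounds than are shown below. What is called first, only, known or untested is meant among the compounds shown, and "the series" means these compounds.

Compound 1, `Cc1cc(C(=O)O)ccc1-c1noc(-c2ccc(C3CCCCC3)cc2)n1`, in a functional assay on CHO cells with sphingosine 1-phosphate receptor 4 (Homo sapiens) as the target, read by GTPgammaS binding (a higher number here means that more compound is needed for the effect, a lower number that less compound is needed), gives > 10000 nM.
Compound 2, `Cc1cc(CCC(=O)O)ccc1-c1noc(-c2ccc(C3CCCCC3)cc2)n1`, in this assay gives > 10000 nM.

The value of compound 1 is a limit of the assay, not a number. The value of compound 2 is likewise a limit. Within the data shown here, the only measured step, a step that the two limits leave unreadable from compound 1 to compound 2, therefore has no readable size. Compound 2 stands at the limit of > 10000 nM in this assay, at which 2 of the 2 values shown sit, and the second value shown sits at the same limit, so nothing places it higher or lower than compound 1.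

Compound 3, `Cc1cc(CCCC(=O)O)ccc1-c1noc(-c2ccc(C3CCCCC3)cc2)n1`, differs from compound 2 by carboxymethyl in place of carboxy on a saturated chain carbon, two bonds along the chain from an aromatic carbon. Among the measured compounds shown here, the one measured step that bears on this change, the one from compound 1 to compound 2, is itself unreadable, so it gives no direction and no size to carry over. For the measured compounds named here, what the two measured compounds show is only that neither chain length so far has brought the value under the limit.

Compound 3 is therefore expected to remain at the limit as well, with an estimated value of 15000 nM, ranging from 4000 nM to 60000 nM. The expected step is a step that the limit leaves unreadable from compound 2 to compound 3, no more than scatter.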

Compound 3, half-maximal effective concentration: > 10000 nM
Compound 3: no number, only a limit; the forecaster's own chance of this, stated with the estimate: 85%; the middle value is on the limit's open side.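

In this assay compound 3 gives > 10000 nM, again a limit of the assay and not a number. The steps among compound 1, compound 2 and compound 3 therefore cannot be read, and all three compounds share one limit: the limit of > 10000 nM in this assay, at which 3 of the 3 values shown sit.

The compounds shown leave open how far past this limit each one lies, and whether the length of the acid chain changes the value at all.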